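The compounds below may be only part of what the source reports. "The series", "measured", "known", "first", "only" and "open" are said of these compounds alone.

In a functional assay on SW-620 cells (Homo sapiens) for cytotoxicity (on this read-out higher numbers stand for weaker inhibition of growth and lower numbers for stronger inhibition of growth), compound 1 (`CSc1ccc(C2=C(c3ccc(F)c(F)c3)C(=O)N3CCCC3C2)cc1`) gives 200 nM and compound 2 (`CSc1ccc(C2=C(c3ccc(Br)cc3)C(=O)N3CCCC3C2)cc1`) gives 7000 nM as the higher of the two numbers, so compound 2 stands at the weak end of what has been measured. Among the compounds with values here, the one measured step is a 35-fold higher number from compound 1 to compound 2 (1.54 log units; beyond the scatter) when 4-bromophenyl replaces 3,4-difluorophenyl on a double-bonded ring carbon. Compound 3 (`CSc1ccc(C2=C(c3ccc(SC)cc3)C(=O)N3CCCC3C2)cc1`) alters that same group again. The change is methylsulfanyl in place of bromo on an aromatic carbon with methylsulfanyl in place of bromo on an aromatic carbon, para to a large group. Within the data shown here, the step of a 35-fold higher number from compound 1 to compound 2 (1.54 log units; beyond the scatter) is the only guide. Among the measured compounds shown here, it shows that this group can move the number in this assay strongly, but it involves a different change, and no measured compound carries methylsulfanyl at this place. With compound 2 at 7000 nM as the high mark, a moderate shift toward a lower number is expected, smaller than the measured step. The expected step is a 3.5-fold lower number from compound 2 to compound 3 (0.54 log units; beyond the scatter) on this reasoning, though with wide uncertainty. Compound 3 is thus estimated at 2000 nM with 400 nM and 9000 nM as the expected ends of its range.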

Compound 3, concentration for 50% growth inhibition: 7000 nM
Compound 3: middle estimate off by 3.5-fold (0.54 log units), on the low side; the range from low to high includes it.
By their numbers in this assay, from the lowest: compound 1; then compounds 2 and 3 (each within the scatter of the next).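

In this assay, the step is no change at the digits printed from compound 2 to compound 3 (within the scatter) when methylsulfanyl takes the place of bromo on the aromatic carbon para to a large group, so at this place the two groups cannot be told apart, even though they differ in heavy-atom count and only methylsulfanyl counts as a hydrogen-bond acceptor. The large earlier step also returns as a 35-fold higher number from compound 1 to compound 3 (1.54 log units; beyond the scatter) on going from 3,4-difluorophenyl to 4-(methylsulfanyl)phenyl, so among these three compounds the gap to compound 1 is the same whichever of the two groups is present. Nothing at hand explains this result.

Going by these compounds, whether a single fluoro group or a plain phenyl at this place would sit with compound 1 or with compounds 2 and 3 remains open, so the part of 3,4-difluorophenyl that goes with the lower number cannot be identified. Also open, on these data alone, is whether an amine or a carboxylic acid on the same aromatic carbon would give a number different from those of compounds 2 and 3.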